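The source may hold more compounds than are shown below. What is called first, only, known or untested is meant among the compounds shown, and "the series" means these compounds.

In a functional assay on A549 cells (Homo sapiens) for antiproliferative activity, read by MTT assay, with a stated time of 48 h (on this read-out higher numbers stand for weaker inhibition and lower numbers for stronger inhibition), compound 1 (`Cn1cc(C2=C(c3nn(CCCN4CCCCC4)c4ncccc34)C(=O)N(c3ccccc3)C2=O)c2ccccc21`) gives 20600 nM and compound 2 (`CN(C)CCCn1nc(C2=C(c3cn(C)c4ccccc34)C(=O)N(c3ccccc3)C2=O)c2cccnc21`) gives 13000 nM on the same read-out. These two numbers lie within the scatter of each other, so compound 2 has no place apart from compound 1 so far.

Compound 3 (`Cn1cc(C2=C(c3nn(CCCn4cccc4)c4ncccc34)C(=O)N(c3ccccc3)C2=O)c2ccccc21`) follows from compound 2 by one change: 1H-pyrrol-1-yl in place of dimethylamino on a saturated chain carbon, three bonds along the chain from an aromatic nitrogen on the chain, which turns 3-(dimethylamino)propyl into 3-(1H-pyrrol-1-yl)propyl.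

Within the data shown here, only one measured step bears on this position: a 1.6-fold lower number from compound 1 to compound 2 (0.20 log units; within the scatter) for dimethylamino in place of piperidin-1-yl. Among the measured compounds shown here, it stays within the scatter, but neither of its end groups is an aromatic ring, and no measured compound carries 1H-pyrrol-1-yl, so it is weak guidance. No step beyond the scatter is therefore expected in this assay, with perhaps a slight drift towards a higher number. The estimated step is a 1.4-fold higher number from compound 2 to compound 3 (0.14 log units; within the scatter) and the uncertainty around it is wide. For compound 3 the estimated value is 18000 nM with an expected range from 7000 nM to 45000 nM on this read-out.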

Compound 3, half-maximal inhibitory concentration: > 100000 nM
Compound 3: only a limit was reported; the forecaster's own chance of this, stated with the estimate: 10%; middle value at least 5.5-fold (0.74 log units) away from the limit.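

In this assay compound 3 carries a limit and not a number: the limit of > 100000 nM in this assay, at which 1 of the 3 values shown sits. Read against that limit, the group at the end of the chain is no longer without consequence, as 1H-pyrrol-1-yl in place of dimethylamino gives an at least 7.6-fold higher number from compound 2 to compound 3 (0.88 log units; beyond the scatter) and 1H-pyrrol-1-yl in place of piperidin-1-yl gives an at least 4.8-fold higher number from compound 1 to compound 3 (0.68 log units; beyond the scatter). The earlier exchange of the two non-aromatic groups gave only a 1.6-fold lower number from compound 1 to compound 2 (0.20 log units; within the scatter), so among the compounds shown, only the change that brings in a five-membered aromatic ring at this place moves the read-out beyond the scatter, and the size of that step is known only as a lower bound.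

With a single aromatic group at this place, the compounds shown do not separate the presence of a ring of this kind from other differences between 1H-pyrrol-1-yl and the two groups it replaces. On these data alone, it remains open whether imidazol-1-yl, morpholin-4-yl or a primary amine at the end of the chain, or a shorter or longer chain, would stay with compound 1 and compound 2 or go with compound 3.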